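A few compounds are considered here, and "the series" means these few. Any claim that something is new, unique, unknown or untested is made for them only; others in the source may bear on it.

Within the data shown here, in an ADME assay on HepG2 cells (Homo sapiens) for cytotoxicity, read by MTT assay, with a stated time of 24 h (a higher number here means that more compound is tolerated, a lower number that less compound is tolerated), compound 1 `CC(C)=CCC1=C(OCc2cn(-c3cccnc3)nn2)C(=O)c2ccccc2C1=O` gives 1030000 nM, the second highest of the three numbers so far. Compound 3 `CC(C)=CCC1=C(OCc2cn(-c3ccc(Cl)cc3)nn2)C(=O)c2ccccc2C1=O` gives 1150000 nM, and compound 2 `CC(C)=CCC1=C(OCc2cn(-c3ccccc3)nn2)C(=O)c2ccccc2C1=O` gives 100000 nM.

Compound 4 `COc1ccc(-n2cc(COC3=C(CC=C(C)C)C(=O)c4ccccc4C3=O)nn2)cc1` has not yet been measured. It differs from compound 1 in one place: 4-methoxyphenyl in place of pyridin-3-yl on an aromatic nitrogen.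

Among the measured compounds shown here, two measured steps bear on this change, since both also replace the same group on the same aromatic nitrogen of compound 1. The first is a 10-fold lower number from compound 1 to compound 2 (1.01 log units; beyond the scatter), a large drop. The second is a 1.1-fold higher number from compound 1 to compound 3 (0.05 log units; within the scatter), which stays within the scatter. The gap between those two outcomes is itself large, as a 12-fold higher number from compound 2 to compound 3 (1.06 log units; beyond the scatter) shows, so a carbon-only ring here can land at very different tolerated concentrations. For the measured compounds named here, the 4-methoxyphenyl carries one hydrogen-bond acceptor, as the pyridin-3-yl does, but no measured compound shows how that plays out.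

With a drop in one case and no change in the other, a moderate decrease is expected for compound 4, estimated at 400000 nM in this assay, with a range from 80000 nM to 1500000 nM; this means an expected step of a 2.6-fold lower number from compound 1 to compound 4 (0.41 log units; beyond the scatter).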

Compound 4, half-maximal cytotoxic concentration: 200000 nM
Compound 4: middle estimate off by 2.0-fold (0.30 log units), on the high side; the range from low to high includes it.
By their numbers in this assay, from the lowest: compounds 2 and 4 (each within the scatter of the next); then compounds 1 and 3 (each within the scatter of the next).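

In this assay, the swap keeps the hydrogen-bond acceptor count unchanged, yet it still gives a 5.2-fold lower number from compound 1 to compound 4 (0.71 log units; beyond the scatter), so matching that count does not preserve the number seen for compound 1. The group on the carbon-only ring also matters: methoxy in place of chloro gives a 5.8-fold lower number from compound 3 to compound 4 (0.76 log units; beyond the scatter), while methoxy in place of hydrogen gives a 2.0-fold higher number from compound 2 to compound 4 (0.30 log units; within the scatter), which lies within the scatter, so compound 4 groups with compound 2 and not with compound 3. Nothing measured here explains why these groups differ.

On these data alone, it remains open whether the high number of compound 3 is particular to chloro or would be shared by other groups on the ring. A 4-fluorophenyl, a 4-methylphenyl or a 4-aminophenyl on the same aromatic nitrogen would help to separate these possibilities.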